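Working notes: cytotoxicity across compounds 1 to 4

The compounds below may be only part of what the source reports. "The series", "measured", "known", "first", "only" and "open" are said of these compounds alone.

Measured compounds and their values:
Compound 1 `CC1=C(c2ccc3ccccc3c2)S(=O)(=O)N(Cc2ccc(C(=O)N3CCCCC3)cc2)C1=O`, which in an ADME assay on RAW264.7 cells (Mus musculus) for cytotoxicity, read by WST assay (on this read-out lower numbers stand for higher toxicity in this test and higher numbers for lower toxicity in this test), gives 47900 nM.
Compound 2 `O=C(NCc1ccco1)c1ccc(CN2C(=O)c3ccccc3S2(=O)=O)cc1`, for which this assay gives only a limit, > 100000 nM.
Compound 3 `CC(C)(C)OC(=O)N(Cc1ccco1)C(=O)c1ccc(Cn2oc3ccccc3c2=O)cc1`, for which this assay again gives only a limit, > 100000 nM.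

Compound 2 stands at a limit of this assay rather than at a number. One further value shown is likewise a limit: the limit of > 100000 nM in this assay, at which 2 of the 3 values shown sit. Going by the values given here, only compound 1 carries a numerical value, and no pair of measured compounds differs in a single place, so no measured step is available.

Compound 4 `CN(C(=O)OC(C)(C)C)C(=O)c1ccc(CN2C(=O)c3ccccc3S2(=O)=O)cc1` is not yet measured in this assay. It differs from compound 2 as follows: methyl(tert-butoxycarbonyl)amino in place of ((furan-2-yl)methyl)amino on a carbonyl carbon. Among the compounds with values here, with no measured step to lean on, no step beyond the usual scatter is expected in either direction, and the most likely outcome is that compound 4 also returns a limit in this assay. The estimate for compound 4 is therefore 100000 nM, with a range from 50000 nM to 200000 nM. This estimate amounts to an expected step of a number no higher from compound 2 to compound 4 (the limit leaves the size open).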

Compound 4, concentration lethal to 50% of the cells: > 100000 nM
Compound 4 was reported as a limit; the forecaster's own chance of this, stated with the estimate: 70%; the middle value lies on the limit itself.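

Compound 2 and compound 4 both return a limit in this assay, so no step can be read between them: the limit of > 100000 nM in this assay, at which 3 of the 4 values shown sit.

The compounds shown leave open whether methyl(tert-butoxycarbonyl)amino in place of ((furan-2-yl)methyl)amino on a carbonyl carbon changes the read-out of this assay at all, and in which direction.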